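Biguanide series: cyclopentyl replacing isobutyl on the amine nitrogen

The source may hold more compounds than are shown below. What is called first, only, known or untested is meant among the compounds shown, and "the series" means these compounds.

Two compounds of the series carry numbers in a functional assay on T-24 cells (Homo sapiens) for antiproliferative activity, read by MTT assay, with a stated time of 72 h; on this read-out higher numbers stand for weaker inhibition and lower numbers for stronger inhibition. Compound 1 `CCN(C)C(=N)NC(=N)Nc1ccc(C(F)(F)F)cc1` gives 5700 nM in this assay. Compound 2 `CC(C)CNC(=N)NC(=N)Nc1ccc(F)cc1F` gives 40800 nM in this assay, the highest of the two numbers, and its gap to compound 1 is beyond the scatter. The two compounds differ in more than one place, so nothing is drawn from that gap beyond what the two values show.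

Compound 3 `N=C(NC(=N)NC1CCCC1)Nc1ccc(F)cc1F` is not yet measured in this assay. It differs from compound 2 in one place: cyclopentyl in place of isobutyl on an amine nitrogen. Going by the values given here, both groups are of similar size and bring no donors or acceptors, and no measured pair of the series shows this change, so a step of little size is expected, or none beyond the scatter. Compound 3 is expected to give 30000 nM in this assay, within 12000 nM to 80000 nM. The expected step is a 1.4-fold lower number from compound 2 to compound 3 (0.13 log units; within the scatter).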

Compound 3, half-maximal inhibitory concentration: 37800 nM
Compound 3: middle estimate off by 1.3-fold (0.10 log units), on the low side; the measured number falls inside the stated range.
By their numbers in this assay, from the lowest: compound 1; then compounds 3 and 2 (each within the scatter of the next).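

In this assay, going by these compounds alone, the first single-place comparison of the series gives a 1.1-fold lower number from compound 2 to compound 3 (0.03 log units; within the scatter) for cyclopentyl in place of isobutyl on an amine nitrogen. At this position, in this pair, the one additional carbon and the closure of the chain into a five-membered ring leave the read-out indistinguishable, so compound 2 and compound 3 stand as equivalents here. No supporting measurement bears on why the two compounds read alike.

One pair cannot show whether this nitrogen accepts any substituent or only these two similarly sized carbon groups. On these data alone, a phenyl ring, a longer chain such as n-octyl or a chain ending in an amine at this position remains open, as does whether the exchange reads the same with the trifluoromethyl-bearing aryl group of compound 1.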